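From Phenyl to 4-Hydroxyphenyl in Compound 2

A few compounds are considered here, and "the series" means these few. Any claim that something is new, unique, unknown or untested is made for them only; others in the source may bear on it.

In a functional assay on HeLa cells (Homo sapiens) for antiproliferative activity, read by MTT assay, with a stated time of 72 h (a higher number here means a weaker inhibitor, a lower number a stronger inhibitor), compound 1 `Nc1nc(N)c2cc(CSC(=S)N3CCN(C4CCCCC4)CC3)ccc2n1` gives 5960 nM. Compound 2 `Nc1nc(N)c2cc(CSC(=S)N3CCN(c4ccccc4)CC3)ccc2n1` gives 2840 nM, the lower of the two numbers and so the stronger inhibitor of the pair. Going by the values given here, the only measured step, phenyl in place of cyclohexyl on an amine nitrogen in a ring, is a 2.1-fold lower number from compound 1 to compound 2 (0.32 log units; beyond the scatter). It is a modest step, and it touches the same substituent that changes next.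

Compound 3 `Nc1nc(N)c2cc(CSC(=S)N3CCN(c4ccc(O)cc4)CC3)ccc2n1` keeps everything in compound 2 except for one place: hydroxy in place of hydrogen on an aromatic carbon, para to a large group, turning phenyl into 4-hydroxyphenyl (hydroxy in place of hydrogen on an aromatic carbon). Among the compounds with values here, no measured compound carries a hydroxy group, so the data give no direction for this change. Within the data shown here, the single exchange of a whole ring moved the number only from compound 1 with 5960 nM to compound 2 with 2840 nM, so a smaller edit on that ring is expected to produce no step beyond the scatter.

The estimate amounts to a 1.1-fold lower number from compound 2 to compound 3 (0.06 log units; within the scatter). For compound 3, the expected value is 2500 nM, with an estimated range of 1000 nM to 6500 nM.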

Compound 3, half-maximal inhibitory concentration: 5180 nM
For compound 3 the middle estimate is 2.1-fold (0.32 log units) below the measured one, within the range that was stated.
By their numbers in this assay, from the lowest: compounds 2, 3 and 1 (each within the scatter of the next, the first and the last beyond it).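

Placing a hydroxy group on the aromatic carbon, para to a large group, gives a 1.8-fold higher number from compound 2 to compound 3 (0.26 log units; within the scatter) in this assay, so this single edit cannot be told apart from no change at all. Exchanging cyclohexyl for 4-hydroxyphenyl on the amine nitrogen in the ring gives a 1.2-fold lower number from compound 1 to compound 3 (0.06 log units; within the scatter), so a ring exchange that separated the numbers when the incoming ring was plain phenyl does not separate them when that ring is 4-hydroxyphenyl. The three compounds therefore form an overlapping series in which compound 3 cannot be distinguished from either neighbour, even though compound 1 and compound 2 are distinguished from each other, and nothing available here offers an explanation for the numbers.

Going by these compounds, it remains open whether a methoxy group, a fluorine atom or an amino group on the same aromatic carbon would give a number that stands clear of compound 2. On these data alone, it also remains open whether a benzyl group or a longer alkyl chain on that amine nitrogen would move the number beyond the narrow span these three compounds cover.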